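This account rests on a few compounds, and the source may have more. Where it says the series, first, only, none or still open, it means among the compounds named here.

Measured compounds:
Compound 1, `O=C(Nc1nc(-c2ccccc2)nc2c1nnn2Cc1ccccc1)c1ccc(Cl)cc1`: 108 nM
Compound 2, `O=C(Nc1nc(-c2ccccc2)nc2c1nnn2Cc1ccccc1)c1ccoc1`: 10 nM

Both compounds were tested in an assay (strain Wistar) for displacement of a labelled ligand from adenosine receptor A1 (Rattus norvegicus), read by scintillation counting; on this read-out higher numbers stand for weaker inhibition and lower numbers for stronger inhibition. Among the measured compounds shown here, of the two numbers, compound 2 gives the lowest, so on this read-out it is the stronger of the pair; the only measured step, an 11-fold lower number from compound 1 to compound 2 (1.03 log units; beyond the scatter), lies well beyond the scatter and concerns the group on the carbonyl carbon. Compound 3, `COc1ccc(Cl)cc1C(=O)Nc1nc(-c2ccccc2)nc2c1nnn2Cc1ccccc1`, has not yet been tested in this assay. Its difference from compound 2 is 5-chloro-2-methoxyphenyl in place of furan-3-yl on a carbonyl carbon. For the measured compounds named here, this change is the one measured step run the other way, from a five-membered ring back to a six-membered carbon ring, now carrying a methoxy group as well as the chlorine. Going by the values given here, since compound 1 gives 108 nM with a chlorophenyl group, a higher number than compound 2 is expected, though the methoxy group has no precedent here. The expected step is a 6.0-fold higher number from compound 2 to compound 3 (0.78 log units; beyond the scatter). Compound 3 is therefore estimated at 60 nM, within 15 nM to 250 nM.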

Compound 3, inhibition constant: 7150 nM
The estimate for compound 3 lay 120-fold (2.08 log units) below the measured number; the measured number lies above the stated range.
By their numbers in this assay, from the lowest: compound 2; then compound 1; then compound 3.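

In this assay, the group on the carbonyl carbon can shift the number much further than the first pair showed: 5-chloro-2-methoxyphenyl in place of furan-3-yl gives a 720-fold higher number from compound 2 to compound 3 (2.85 log units; beyond the scatter). The change also separates two chlorine-bearing six-membered aromatic rings, since 5-chloro-2-methoxyphenyl in place of 4-chlorophenyl gives a 66-fold higher number from compound 1 to compound 3 (1.82 log units; beyond the scatter), so carrying a chlorine on such a ring does not by itself fix the number at this position. No measurement here explains why these groups differ so strongly.

The three compounds cannot show whether the methoxy group, the place of the chlorine or both lie behind the rise, a question that plain phenyl and 2-methoxyphenyl groups could help to separate. On these data alone, it also remains open whether other rings on the carbonyl carbon, such as thiophen-3-yl or cyclopropyl, would give numbers as low as furan-3-yl.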